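The source may hold more compounds than are shown below. What is called first, only, known or untested is meant among the compounds shown, and "the series" means these compounds.

Measured compounds in a functional assay on OVCAR-5 cells (Homo sapiens) for inhibition; on this read-out higher numbers stand for weaker inhibition of growth and lower numbers for stronger inhibition of growth:
compound 1, `O=C(/C=C/c1cccc(O)c1)c1cccc(-n2cc(-c3ccc(Cl)cc3)[nH]c2=O)c1`, this assay 2190 nM
compound 2, `COc1ccc(-c2cn(-c3cccc(C(=O)/C=C/c4ccc(O)c(OC)c4)c3)c(=O)[nH]2)cc1`, this assay 3380 nM

Compound 2 sits at the upper end of the two numbers, but its gap to compound 1 lies within the scatter, so the two are not distinguished. Compound 3, `COc1cc(/C=C/C(=O)c2cccc(-n3cc(-c4ccc(Cl)cc4)[nH]c3=O)c2)ccc1O`, is not yet measured. It differs from compound 2 by chloro in place of methoxy on an aromatic carbon, that is, 4-methoxyphenyl to 4-chlorophenyl. Nothing measured resolves this change on its own; compound 1 carries the same chloro group and gives a number within the scatter of compound 2. The step from compound 2 to compound 3 is expected to be a 1.4-fold lower number from compound 2 to compound 3 (0.13 log units; within the scatter), none beyond the scatter. Compound 3 is estimated at 2500 nM, range 1000 nM to 6000 nM.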

Compound 3, concentration for 50% growth inhibition: 2000 nM
Estimate against measurement, compound 3: 1.3-fold (0.10 log units) above; the range from low to high includes it.
By their numbers in this assay, from the lowest: compounds 3, 1 and 2 (each within the scatter of the next).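

In this assay, the direct step at this position, 4-methoxyphenyl to 4-chlorophenyl, gives a 1.7-fold lower number from compound 2 to compound 3 (0.23 log units; within the scatter), so chloro and methoxy are not distinguished on this aromatic carbon. With the chloro group held constant, 4-hydroxy-3-methoxyphenyl in place of 3-hydroxyphenyl on the double-bonded chain carbon gives a 1.1-fold lower number from compound 1 to compound 3 (0.04 log units; within the scatter), so that change is not resolved either. No measured evidence bears on these results.

Going by these compounds, whether an amine or a carboxylic acid on this aromatic carbon would give a step beyond the scatter remains open. The same question stands for a longer chain in place of methoxy.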